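This account rests on a few compounds, and the source may have more. Where it says the series, first, only, none or still open, it means among the compounds named here.

Working notes on the benzophenone-amide series, on the step from compound 2 to compound 4.

Compound 2 `CCCCCC(=O)NCC(=O)N(C)c1ccc(Cl)cc1C(=O)c1ccccc1Cl` stands lowest of the two numbers in a functional assay on the whole organism for antagonist activity, with Mus musculus as the target (on this read-out lower numbers stand for an effect already at smaller amounts and higher numbers for an effect only at larger amounts of compound), at 1.9 mg/kg. Compound 1 `NC(C(=O)NCC(=O)Nc1ccc(Cl)cc1C(=O)c1ccccc1)c1ccccc1` sits at a higher number in this assay, giving 28 mg/kg. For compound 3 `CC(=O)NCC(=O)Nc1ccc(Cl)cc1C(=O)c1ccccc1Cl` this assay returns only a limit, > 100 mg/kg; one of the three values sits at this limit (the limit of > 100 mg/kg in this assay, at which 1 of the 3 values shown sits). Among the measured compounds shown here, no single-point step between measured compounds is available, so the gap from compound 2 to compound 1 is read only as two values that differ in more than one place.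

Compound 4 `CCN(CC)CC(=O)NCC(=O)N(C)c1ccc(Cl)cc1C(=O)c1ccccc1Cl` is not yet measured. It differs from compound 2 as diethylamino in place of butyl on a saturated chain carbon bound to a carbonyl carbon. For the measured compounds named here, the exchange keeps the chain length close and adds one acceptor on a saturated chain carbon bound to a carbonyl carbon; no measured pair isolates such a change. The expectation for the step from compound 2 to compound 4 in this assay is therefore a small move toward higher numbers, a 2.1-fold higher number from compound 2 to compound 4 (0.32 log units; beyond the scatter), possibly within the scatter. Compound 4 is expected to give about 4 mg/kg in this assay, between 1.5 mg/kg and 12 mg/kg.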

Compound 4, dose for half-maximal effect: 2.2 mg/kg
Estimate against measurement, compound 4: 1.8-fold (0.26 log units) above, within the range that was stated.
By their numbers in this assay, from the lowest: compounds 2 and 4 (each within the scatter of the next); then compound 1. At a limit, above all of these: compound 3.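

In this assay the exchange of butyl for diethylamino on a saturated chain carbon bound to a carbonyl carbon reads as a 1.2-fold higher number from compound 2 to compound 4 (0.06 log units; within the scatter) and is the only single-place step shown in the series. Among the compounds shown here, this place on the chain thus carries either butyl or diethylamino, with its nitrogen and its hydrogen-bond acceptor, at values within the scatter of each other, which the earlier compounds could not show, as they differ in more than one place. No measured property shown bears on this step, so nothing can be said about what lies behind it.

As far as these compounds go, how a carboxylic acid, a morpholine ring or a longer chain would read at this carbon remains open. Also open, from the compounds shown here alone, is what the methyl on the amide nitrogen contributes, since compound 2 and compound 3 differ in more than one place.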